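Amide-to-urea swap on the anilide arm

This account rests on a few compounds, and the source may have more. Where it says the series, first, only, none or still open, it means among the compounds named here.

For the measured compounds named here, compound 3 `COc1cc(-c2nn(-c3cccc(NC(=O)c4cccc(C(F)(F)F)c4)c3)cc2-c2ccncc2)ccc1Cl` stands second highest of the three numbers so far in a functional assay on SK-MEL-2 cells (Homo sapiens) for inhibition, read by sulforhodamine B assay, with a stated time of 48 h (a higher number here means a weaker inhibitor of growth, a lower number a stronger inhibitor of growth), where compound 3 gives 1560 nM. Compound 1 `O=C(Nc1cccc(-n2cc(-c3ccncc3)c(-c3ccc(Cl)c(O)c3)n2)c1)Nc1cccc(C(F)(F)F)c1` gives 2020 nM in this assay, and compound 2 `COc1cc(-c2nn(-c3cccc(NC(=O)Nc4cc(C(F)(F)F)cc(C(F)(F)F)c4)c3)cc2-c2ccncc2)ccc1Cl` gives 1020 nM in this assay. Going by the values given here, both of these lie within the scatter of compound 3, so no order among the three compounds can be read from the numbers, and no single-point step between measured compounds has been counted in this set.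

Compound 4 `COc1cc(-c2nn(-c3cccc(NC(=O)Nc4ccc(Cl)c(Cl)c4)c3)cc2-c2ccncc2)ccc1Cl` is not yet measured. It differs from compound 3 by (3,4-dichlorophenyl)amino in place of 3-(trifluoromethyl)phenyl on a carbonyl carbon, which turns the amide of compound 3 into a urea of the kind carried by compound 1 and compound 2. The urea compound 2 with 1020 nM and the amide compound 3 with 1560 nM sit within the scatter of each other, so the amide-to-urea change alone gives no sign of a shift. The expected step from compound 3 to compound 4 in this assay is therefore a 1.3-fold lower number from compound 3 to compound 4 (0.11 log units; within the scatter), nothing beyond the scatter, leaning if anything toward a lower number. Compound 4 is estimated at 1200 nM in this assay, with a range from 500 nM to 3000 nM.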

Compound 4, concentration for 50% growth inhibition: 1140 nM
The estimate for compound 4 lay 1.1-fold (0.02 log units) above the measured number; the range from low to high includes it.
By their numbers in this assay, from the lowest: compounds 2, 4, 3 and 1 (each within the scatter of the next).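

In this assay, for the compounds shown here, a 1.4-fold lower number from compound 3 to compound 4 (0.14 log units; within the scatter) is the first step between measured compounds that differ in one place, and it stays within the scatter. On this carbonyl carbon, the number therefore does not separate the urea carrying (3,4-dichlorophenyl)amino from the amide carrying 3-(trifluoromethyl)phenyl, although the change adds a hydrogen-bond donor and replaces the trifluoromethyl-bearing ring with a dichlorinated one. No measurement at hand bears on the reason for this result.

This single step changes the linkage and the ring substituents together, so the contribution of each remains unresolved, and a urea and an amide with the same aryl group on the same core would be needed to separate them. As far as these compounds go, it also remains open whether any group on this carbonyl carbon moves the number beyond the scatter, for example a piperidine in place of the aryl group or a carboxylic acid on the aryl ring.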